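The source may hold more compounds than are shown below. What is called first, only, known or untested is meant among the compounds shown, and "the series" means these compounds.

Measured in a toxicity assay on the whole organism (strain Icem-CET (SPF Caw)) for cytotoxicity, with Mus musculus as the target; a higher number here means that more compound is needed for the effect, a lower number that less compound is needed:
Compound 1 `C#CCNC(=O)/C(C)=C(\C)c1ccccc1`: 150 mg/kg
Compound 2 `C/C(C(=O)NC1CC1)=C(/C)c1ccccc1`: 100 mg/kg
Compound 3 `C=CCNC(=O)/C(C)=C(\C)c1ccc(C)cc1`: 100 mg/kg

Compound 3 stands level with compound 2 at the digits shown, and the value of compound 1 lies within the usual scatter of both, so the three numbers cannot be told apart with confidence. Compound 4 `C=CCNC(=O)/C(C)=C(\C)c1ccccc1` differs from compound 3 by hydrogen in place of methyl on an aromatic carbon. For the measured compounds named here, the only measured step, a 1.5-fold lower number from compound 1 to compound 2 (0.18 log units; within the scatter), changed the group on the amide nitrogen, not the aromatic ring, and stayed within the scatter. Going by the values given here, no measured step touches the ring, so nothing here points to a change beyond the scatter. Compound 4 is therefore expected to give about 100 mg/kg, with a range from 55 mg/kg to 180 mg/kg. This estimate amounts to no change at the digits printed from compound 3 to compound 4 (within the scatter).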

Compound 4, dose for half-maximal effect: 130 mg/kg
For compound 4 the middle estimate is 1.3-fold (0.11 log units) below the measured one; measured number inside the range.
By their numbers in this assay, from the lowest: compounds 2, 3, 4 and 1 (each within the scatter of the next).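

In this assay, for the compounds shown here, the only step on the aromatic ring, hydrogen in place of methyl para to a large group, is a 1.3-fold higher number from compound 3 to compound 4 (0.11 log units; within the scatter) and shows that this methyl can go without a difference beyond the scatter. Allyl on the amide nitrogen also cannot be told apart from the other two groups, with a 1.3-fold higher number from compound 2 to compound 4 (0.11 log units; within the scatter) for the swap from cyclopropyl and a 1.2-fold lower number from compound 1 to compound 4 (0.06 log units; within the scatter) for the swap from propargyl. Nothing available explains these numbers. As far as these compounds go, whether a chlorine atom, a methoxy group or an amine in this ring position would move the number beyond the scatter stays open.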